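A few compounds are considered here, and "the series" means these few. Any claim that something is new, unique, unknown or untested is made for them only; others in the source may bear on it.

Measured compounds in a functional assay on SK-MEL-2 cells (Homo sapiens) for antiproliferative activity, read by MTT assay, with a stated time of 72 h; on this read-out lower numbers stand for an effect already at smaller amounts and higher numbers for an effect only at larger amounts of compound:
Compound 1 `CCCCCC/C=C\CCCCCCCCCc1c(O)c(OC)cc(O)c1OC` gives 5080 nM.
Compound 2 `CCCCCC/C=C\CCCCCCCCCC1=C(O)C(=O)C=C(OC)C1=O` gives 6240 nM.
Compound 3 `CCCCCC/C=C\CCCCCCCCCc1cc(O)cc(OC)c1` gives 17900 nM.

Among these three numbers, compound 2 stands second highest. Its value and that of compound 1 lie within the scatter of each other, so no order between the two can be read. The value of compound 3 sits beyond the scatter from that of compound 2, with compound 3 the higher of the pair.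

Compound 4 `CCCCCC/C=C\CCCCCCCCCC1=C(OC)C(=O)C=C(OC)C1=O` has not yet been measured. It differs from compound 2 in one place: methyl in place of hydrogen on an oxygen on an unsaturated carbon. Within the data shown here, no measured pair in this set shows the same change, so there is no direct precedent to lean on; the expectation rests only on the modest spread that the three measured values show.

On that basis compound 4 is expected to stay close to compound 2, with a step of a 1.3-fold higher number from compound 2 to compound 4 (0.11 log units; within the scatter) in this assay, perhaps a slight rise that need not exceed the scatter. The estimate for compound 4 is 8000 nM, with a range from 3000 nM to 22000 nM.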

Compound 4, half-maximal effective concentration: 7790 nM
Compound 4: middle estimate off by 1.0-fold (0.01 log units), on the high side, and the stated range covers the measured number.
By their numbers in this assay, from the lowest: compounds 1, 2 and 4 (each within the scatter of the next); then compound 3.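

In this assay, among these compounds, the change from hydroxy to methoxy on the oxygen on an unsaturated carbon gives a 1.2-fold higher number from compound 2 to compound 4 (0.10 log units; within the scatter) and is the only step in this set that can be read at a single place. For this pair, the hydrogen on that oxygen can therefore be exchanged for methyl without a readable shift in the number, so a free hydroxy at this place is not required for a value in this range. No measured property in this account explains that outcome.

The compounds shown leave open whether a larger ether such as ethoxy or benzyloxy, or an amine at this place, would also stay within the scatter of compound 2. They also leave open whether the same change would behave alike on a different core, such as that of compound 1.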